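The source may report more compounds than this note shows. Statements on the series, on what has been measured and on what is new or still open speak of the compounds shown alone.

Compound 1 `CC1=C(C(=O)Nc2ccc([N+](=O)[O-])cc2)C(c2ccc(Br)cc2)N=C(SCc2ccccc2)N1`: 19.5%
Compound 2 `CC1=C(C(=O)Nc2ccc([N+](=O)[O-])cc2)C(c2ccc(Br)cc2)N=C(SCc2ccccc2Cl)N1`: 4.1%

In a functional assay on the whole organism (artery, strain albino) with Rattus norvegicus as the target, with a stated time of 900 min, at a dose of 10 mg/kg by the oral route (on this read-out lower numbers stand for less inhibition and higher numbers for more inhibition at the one dose given (going by the name of the read-out)), compound 2 stands lowest of the two numbers shown. For the measured compounds named here, the only measured step is a number 15.4 percentage points lower from compound 1 to compound 2 (beyond the scatter), which adds a chloro rather than moving one. Compound 3 `CC1=C(C(=O)Nc2ccc([N+](=O)[O-])cc2)C(c2ccc(Br)cc2)N=C(SCc2cccc(Cl)c2)N1` differs from compound 2 by 3-chlorophenyl in place of 2-chlorophenyl on a saturated chain carbon bound to a sulfur. Going by the values given here, no measured step shifts a chloro from one place on the ring to another, so that step bears on this change only loosely. For compound 3 the expected step is a number 5.9 percentage points higher from compound 2 to compound 3 (within the scatter), within the scatter. Compound 3 is therefore estimated at 10%, with a range from 0% to 25%.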

Compound 3, a percentage reported as inhibition, in the whole organism at one dose (the size of the read-out at that dose, not a potency): 2.6%
Beside the measured number, compound 3's estimate is 7.4 percentage points above it; low and high end bracket the measured number.
By their numbers in this assay, from the lowest: compounds 3 and 2 (each within the scatter of the next); then compound 1.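

Moving the chlorine from 2-chlorophenyl to 3-chlorophenyl in this assay gives a number 1.5 percentage points lower from compound 2 to compound 3 (within the scatter), so these two placements cannot be told apart here. The loss seen on adding chloro to the unsubstituted benzyl group therefore holds for both placements, with a number 16.9 percentage points lower from compound 1 to compound 3 (beyond the scatter). Nothing available explains why chloro lowers the number at either placement.

On these data alone, it remains open whether this loss is specific to chloro or would also appear with a methoxy group, an amine or a carboxylic acid on the same ring.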